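Aryl swap on the triazole nitrogen: expecting no change

The source may report more compounds than this note shows. Statements on the series, on what has been measured and on what is new or still open speak of the compounds shown alone.

Measured so far:
compound 1 `N#CC1=C(N)Oc2c(c3nc4ccccc4nc3c3ccccc23)C12C(=O)N(Cc1cnnn1-c1ccccc1Br)c1ccccc12` — > 50000 nM
compound 2 `N#CC1=C(N)Oc2c(N)cc3nc4ccccc4nc3c2C12C(=O)N(Cc1cnnn1-c1ccc(F)cc1)c1ccccc12` — > 50000 nM

Both values here are limits of the assay rather than numbers. In an ADME assay on HUVEC cells (Homo sapiens) for antiproliferative activity, read by MTT assay, with a stated time of 48 h (a lower number here means a stronger inhibitor, a higher number a weaker inhibitor), compound 1 is reported only as a limit, > 50000 nM. Compound 2 likewise sits at a limit in this assay, > 50000 nM. Where compound 2 stands is therefore told only by the limit of > 50000 nM in this assay, at which 2 of the 2 values shown sit: no number places it, and nothing separates it from compound 1. Compound 3 `Cc1ccc(-n2nncc2CN2C(=O)C3(C(C#N)=C(N)Oc4c(N)cc5nc6ccccc6nc5c43)c3ccccc32)cc1Cl` is not yet measured. It differs from compound 2 by 3-chloro-4-methylphenyl in place of 4-fluorophenyl on an aromatic nitrogen. Among the measured compounds shown here, no step between two measured compounds exists here to gauge such a change, and the two values shown give no ranking. With both reference compounds sitting at the limit, the expected step is a number no higher from compound 2 to compound 3 (the limit leaves the size open), none beyond the scatter. Compound 3 is expected near 50000 nM, within 20000 nM to 100000 nM, most likely again reported only as a limit.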

Compound 3, half-maximal inhibitory concentration: > 50000 nM
Compound 3 ended at the assay's limit; the forecaster's own chance of this, stated with the estimate: 85%; the middle value lies on the limit itself.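

No step can be read from compound 2 to compound 3 in this assay, since each is reported as a limit and not as a number: the limit of > 50000 nM in this assay, at which 3 of the 3 values shown sit. The compounds shown leave open whether any other group on the aromatic nitrogen, or any change to the shared core, would give a measurable value.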